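Removing the methoxy from the pendant phenyl of compound 2

The source may hold more compounds than are shown below. What is called first, only, known or untested is meant among the compounds shown, and "the series" means these compounds.

Two compounds of the series have numbers in a functional assay on BT-549 cells (Homo sapiens) for inhibition, read by sulforhodamine B assay, with a stated time of 48 h; on this read-out higher numbers stand for weaker inhibition of growth and lower numbers for stronger inhibition of growth. Compound 1 `COc1ccc(-c2[nH]c3ccccc3c2/C=C(\C#N)S(=O)(=O)c2ccccc2)cc1` gives 1600 nM in this assay. Going by the values given here, compound 2 `COc1ccc(-c2[nH]c3ccc(OC)cc3c2/C=C(\C#N)S(=O)(=O)c2ccccc2)cc1` gives 4800 nM in this assay, the higher of the two numbers, with compound 1 as its only neighbour. Among the compounds with values here, the one step measured so far, a 3.0-fold higher number from compound 1 to compound 2 (0.48 log units; beyond the scatter), came from a methoxy placed on an aromatic carbon of the shared core.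

Compound 3 `COc1ccc2[nH]c(-c3ccccc3)c(/C=C(\C#N)S(=O)(=O)c3ccccc3)c2c1` keeps that core methoxy and differs from compound 2 in hydrogen in place of methoxy on an aromatic carbon; cut one bond further out, the difference reads 4-methoxyphenyl to phenyl. Within the data shown here, no measured step touches this position. Among the measured compounds shown here, the only step available, a 3.0-fold higher number from compound 1 to compound 2 (0.48 log units; beyond the scatter), concerns a methoxy at a different place and so bears only loosely on this change; it shows that adding a methoxy raised the number modestly, which gives a weak hint that removing one might lower it. The expected step is therefore a 1.6-fold lower number from compound 2 to compound 3 (0.20 log units; within the scatter), a small move toward stronger inhibition of growth, close to the scatter. Compound 3 is estimated at 3000 nM, within 1200 nM to 8000 nM.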

Compound 3, concentration for 50% growth inhibition: 11600 nM
For compound 3 the middle estimate is 3.9-fold (0.59 log units) below the measured one; measured number outside the range, above it.
By their numbers in this assay, from the lowest: compound 1; then compound 2; then compound 3.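

In this assay, taking the methoxy off the pendant ring, 4-methoxyphenyl to phenyl, gives a 2.4-fold higher number from compound 2 to compound 3 (0.38 log units; beyond the scatter), so at this place, para to a large group, the methoxy goes with stronger inhibition of growth and its loss with weaker inhibition. The earlier step, a 3.0-fold higher number from compound 1 to compound 2 (0.48 log units; beyond the scatter), ran the other way in its effect: there a methoxy entering on the shared core went with weaker inhibition, and both steps lie beyond the scatter, so a methoxy has no single direction in this series and its effect has to be read place by place. Nothing measured here accounts for this difference between the two places.

Going by these compounds, it remains open whether the pendant-ring step keeps its direction and size on the core of compound 1, which carries no core methoxy. The compounds shown also leave open whether the step is specific to methoxy or would follow with another group at the same place, such as a hydroxyl, an amine or a longer alkoxy chain.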